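A Dichlorobenzyl Swap on Compound 2

This account rests on a few compounds, and the source may have more. Where it says the series, first, only, none or still open, it means among the compounds named here.

Compound 1 `Cc1ccc(/C=C(/SCc2ccc(Cl)cc2Cl)C(=O)c2ccc(Cl)cc2)s1`: 50000 nM
Compound 2 `Cc1ccc(CS/C(=C/c2c[nH]c3ccc(Br)cc23)C(=O)c2ccc(Cl)cc2)cc1`: 1000 nM

Of the compounds shown here, two have been measured so far in a functional assay on DU-145 cells (Homo sapiens) for inhibition, read by trypan blue exclusion, with a stated time of 96 h; on this read-out lower numbers stand for stronger inhibition of growth and higher numbers for weaker inhibition of growth. Compound 2 gives 1000 nM, the lower of the two numbers, while compound 1 gives 50000 nM. That gap lies beyond the usual scatter of repeated measurements, and it places compound 2 on the side of stronger inhibition of growth.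

Compound 3 `O=C(/C(=C\c1c[nH]c2ccc(Br)cc12)SCc1ccc(Cl)cc1Cl)c1ccc(Cl)cc1` has not yet been measured in this assay. It departs from compound 2 in a single place: 2,4-dichlorophenyl in place of 4-methylphenyl on a saturated chain carbon bound to a sulfur. In words, 2,4-dichlorophenyl stands in place of 4-methylphenyl on a saturated chain carbon bound to a sulfur, which also reads as 4-methylbenzyl to 2,4-dichlorobenzyl.

Within the data shown here, no measured pair isolates this change, so its size cannot be read from the data. The expectation therefore starts from compound 2 at 1000 nM, and no step beyond the scatter is expected in this assay. The estimated step is a 1.3-fold lower number from compound 2 to compound 3 (0.10 log units; within the scatter). For compound 3 the expected value is 800 nM, with an estimated range from 200 nM to 3500 nM.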

Compound 3, concentration for 50% growth inhibition: 10000 nM
Estimate against measurement, compound 3: 13-fold (1.10 log units) below; the whole stated range lies below it.
By their numbers in this assay, from the lowest: compound 2; then compound 3; then compound 1.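

In this assay, the group on the saturated chain carbon bound to a sulfur proves to matter: 4-methylbenzyl to 2,4-dichlorobenzyl gives a 10-fold higher number from compound 2 to compound 3 (1.00 log units; beyond the scatter), so on this core the change is not interchangeable, even though both groups carry one six-membered aromatic ring of carbon only and no hydrogen-bond donors or acceptors. Compound 3 also links the series at a second place, since with 2,4-dichlorobenzyl held constant, 5-bromo-1H-indol-3-yl in place of 5-methylthiophen-2-yl on a double-bonded chain carbon gives a 5.0-fold lower number from compound 1 to compound 3 (0.70 log units; beyond the scatter), which shows that the read-out answers to changes at both places. Nothing measured here speaks to why the dichlorobenzyl group goes with the higher number.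

The compounds shown leave open whether the step comes from gaining the two chlorines or from losing the methyl, a question that a plain benzyl or a 4-chlorobenzyl on the sulfur would address. They also leave open whether the step from 4-methylbenzyl to 2,4-dichlorobenzyl would have the same size on the core of compound 1.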